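The source may report more compounds than this note shows. Statements on the series, on what has been measured and on what is new or still open speak of the compounds shown alone.

Measured in an ADME assay on S9 fraction (Rattus norvegicus) for metabolic stability, with a stated time of 60 min; on this read-out higher numbers stand for a more stable compound and lower numbers for a less stable compound:
- compound 1 `O=c1[nH]c2ncc(-c3ccc(-c4nc[nH]n4)cc3)nc2n1CCC1CCOCC1`: 93%
- compound 2 `O=C1CNc2ncc(-c3ccc(-c4nc[nH]n4)cc3)nc2N1CCC1CCOCC1`: 48%
- compound 3 `CC(C)(O)c1ccc(-c2cnc3c(n2)N(CC2CCCCC2)CC(=O)N3)cn1`: 16%

Of these three, compound 3 stands lowest at 16%, with both other values beyond the scatter above it. Compound 4 `CO[C@H]1CC[C@@H](N2CC(=O)Nc3ncc(-c4ccc(C(C)(C)O)nc4)nc32)CC1` has yet to be measured. It differs from compound 3 in one place, with 4-methoxycyclohexyl in place of cyclohexylmethyl on a nitrogen on an aromatic ring in a ring.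

For the measured compounds named here, no two measured compounds differ in only one place, so no measured step speaks directly to this change. Going by the values given here, the only indirect guide is that the groups at this nitrogen in compound 1 and compound 2 also contain an oxygen. Compound 2 gives 48% and compound 1 gives 93%, but both also differ from compound 3 elsewhere, so this support is weak. A moderate rise, probably beyond the scatter, is therefore expected, estimated as a number 16 percentage points higher from compound 3 to compound 4 (beyond the scatter). For compound 4, the estimated value is 32%, with an expected range of 14% to 55%.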

Compound 4, percent of the compound remaining: 87%
Compound 4: middle estimate off by 55 percentage points, on the low side; measured number above the stated range.
By their numbers in this assay, from the lowest: compound 3; then compound 2; then compounds 4 and 1 (each within the scatter of the next).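

In this assay, for the compounds shown here, 4-methoxycyclohexyl in place of cyclohexylmethyl on this nitrogen gives a number 71 percentage points higher from compound 3 to compound 4 (beyond the scatter), the first step here that can be read at a single place. With the rest of the structure held constant, the group at this nitrogen alone is enough to move the read-out by a large margin. Nothing measured here gives a reason for this rise.

The step exchanges the whole group at once, so the share of the methoxy oxygen remains unresolved, and a plain cyclohexyl or a 4-hydroxycyclohexyl group at this nitrogen would bear on that question. Going by these compounds, the role of the two defined stereocentres also remains open, as does whether the same change would give a similar step on the core of compound 1 or compound 2.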